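A few compounds are considered here, and "the series" means these few. Any claim that something is new, unique, unknown or untested is made for them only; others in the source may bear on it.

Compound 1 `C/C=C/C(=O)Nc1cccc(Oc2nc(Nc3ccn(C)n3)nc3c2CSCC3)c1`: 40000 nM
Compound 2 `CC(C)/C=C/C(=O)Nc1cccc(Oc2nc(Nc3ccn(C)n3)nc3c2CSCC3)c1`: > 50000 nM
Compound 3 `C=C(F)C(=O)Nc1cccc(Oc2nc(Nc3ccn(C)n3)nc3c2CSCC3)c1`: not yet measured

In a functional assay on MCF7 cells (Homo sapiens) for antiproliferative activity, read by MTT assay, with a stated time of 72 h (on this read-out higher numbers stand for weaker inhibition and lower numbers for stronger inhibition), compound 1 gives 40000 nM. Compound 2 stands only at a limit of the assay, > 50000 nM, not at a number. The move to compound 3 is 1-fluoroethenyl in place of 3-methylbut-1-en-1-yl on a carbonyl carbon. Within the data shown here, the one measured step that bears on this is an at least 1.2-fold higher number from compound 1 to compound 2 (0.09 log units; that floor lies within the scatter), and it offers only a weak guide. Among the measured compounds shown here, with compound 1 at 40000 nM as the sole true number, a modest move towards stronger inhibition is expected, namely an at least 2.0-fold lower number from compound 2 to compound 3 (0.30 log units; that floor lies within the scatter). Compound 3 is estimated at 25000 nM, with an expected range of 6000 nM to 50000 nM.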

Compound 3, half-maximal inhibitory concentration: > 50000 nM
Compound 3 ended at the assay's limit; the forecaster's own chance of this, stated with the estimate: 35%; middle value at least 2.0-fold (0.30 log units) from the limit.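

In this assay compound 3 gives > 50000 nM, a limit of the assay and not a number. Set against the prop-1-en-1-yl group, the 1-fluoroethenyl group gives an at least 1.2-fold higher number from compound 1 to compound 3 (0.09 log units; that floor lies within the scatter), while the step between the two limits cannot be read. So a second, quite different group on this carbonyl carbon also fails to bring a true number: the limit of > 50000 nM in this assay, at which 2 of the 3 values shown sit.

On these data alone, how far compound 2 and compound 3 lie beyond that limit stays open. So does whether a plain ethenyl group or a chain carrying a dimethylamino group on this carbonyl carbon would give stronger inhibition than compound 1.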